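The source may hold more compounds than are shown below. What is called first, only, known or untested is meant among the compounds shown, and "the series" means these compounds.

Compound 1 `OCC#CCSc1cnc2ccccc2c1[Se]CC#CCO` gives 4.3 ug/mL in a functional assay on B16 cells (Mus musculus) for cytotoxicity, read by sulforhodamine B assay, with a stated time of 72 h; a higher number here means a weaker inhibitor, a lower number a stronger inhibitor.
Compound 2 `C#CCSc1cnc2ccccc2c1[Se]CC#CCO` gives 3.6 ug/mL in this assay.
Compound 3 `C#CCSc1cnc2ccccc2c1SCC#CCO` gives 54.7 ug/mL in this assay.

Among these three numbers compound 2 has the lowest; its nearest neighbour is compound 1, and the step of a 1.2-fold lower number from compound 1 to compound 2 (0.08 log units; within the scatter) lies within the scatter, so the two cannot be told apart. Its furthest neighbour is compound 3, reached by the step of a 15-fold higher number from compound 2 to compound 3 (1.18 log units; beyond the scatter), which is large and lies beyond the scatter.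

The unmeasured compound 4 `CSc1cnc2ccccc2c1[Se]CC#CCO` differs from compound 2 in one place: hydrogen in place of ethynyl on a saturated chain carbon bound to a sulfur. The change sits on the chain bound to sulfur, the same chain that was altered between compound 1 and compound 2; that alteration, a 1.2-fold lower number from compound 1 to compound 2 (0.08 log units; within the scatter), stayed within the scatter. The large step of a 15-fold higher number from compound 2 to compound 3 (1.18 log units; beyond the scatter) concerns the other side of the shared core and says nothing about the chain bound to sulfur. One trimming of that chain is thus known to have had little consequence, and the trimming from propargyl to methyl is expected to behave in the same way, giving a step of a 1.4-fold higher number from compound 2 to compound 4 (0.14 log units; within the scatter) that is expected to stay within the scatter or be at most modest. Compound 4 is therefore estimated at 5 ug/mL, within a range from 2 ug/mL to 14 ug/mL in this assay.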

Compound 4, concentration for 50% inhibition: 4.2 ug/mL
Beside the measured number, compound 4's estimate is 1.2-fold (0.08 log units) above it; measured number inside the range.
By their numbers in this assay, from the lowest: compounds 2, 4 and 1 (each within the scatter of the next); then compound 3.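

With compound 4 the chain bound to sulfur has been cut back to methyl in this assay, and neither cut leaves the scatter: removing the ethynyl gives a 1.2-fold higher number from compound 2 to compound 4 (0.07 log units; within the scatter) and removing the whole 3-hydroxyprop-1-yn-1-yl gives a 1.0-fold lower number from compound 1 to compound 4 (0.01 log units; within the scatter). The earlier compounds had shown only that the hydroxymethyl at the end of this chain could be replaced by hydrogen, whereas compound 4 shows that a number of this size does not depend on the triple bond in the chain at all. Across methyl, propargyl and the longer hydroxylated chain, the numbers of compound 1, compound 2 and compound 4 cannot be told apart, so among these compounds only the step of a 15-fold higher number from compound 2 to compound 3 (1.18 log units; beyond the scatter) on the other side of the core goes beyond the scatter. Nothing available explains why this chain makes so little difference.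

The compounds shown leave open how a carboxylic acid or an amine on this chain, or a longer saturated chain in place of methyl, would read in this assay. They also leave open whether the chain bound to sulfur matters as little when sulfur replaces selenium on the other side of the core, as it does in compound 3.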